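Trimming the urea amine in a melanin-concentrating hormone receptor series

The source may report more compounds than this note shows. Statements on the series, on what has been measured and on what is new or still open speak of the compounds shown alone.

The three compounds described so far share one core, a piperidine urea whose basic nitrogen carries a benzyl-type arm bearing a trifluoromethyl-substituted aryl pyrazole, and differ only in the amine on the other side of the urea carbonyl. Compound 1 `CN1CCN(C(=O)NC2CCN(Cc3ccn(-c4ccc(C(F)(F)F)cc4)c3)CC2)C(c2ccccc2)C1` gives 28 nM in an assay on HEK293 cells for displacement of a labelled ligand from melanin-concentrating hormone receptor 1 (Homo sapiens); a higher number here means a weaker inhibitor, a lower number a stronger inhibitor. Compound 2 `COc1ccc(OC2CN(C(=O)NC3CCN(Cc4ccn(-c5ccc(C(F)(F)F)cc5)c4)CC3)C2)cc1` gives 49 nM in this assay. Compound 3 `O=C(NC1CCN(Cc2ccn(-c3ccc(C(F)(F)F)cc3)c2)CC1)N1CCCCC1CCO` gives 39 nM in this assay; its number falls between those of the other two, with the gap to compound 2 and the gap to compound 1 both within the usual scatter, so the three read as essentially alike.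

The next compound, compound 4 `O=C(NC1CCN(Cc2ccn(-c3ccc(C(F)(F)F)cc3)c2)CC1)N1CC[C@H](O)C1`, keeps everything except the amine on the carbonyl. 3-hydroxypyrrolidin-1-yl in place of 2-(2-hydroxyethyl)piperidin-1-yl on a carbonyl carbon The ring shrinks and the hydroxyl moves onto the ring itself rather than a side chain.

Going by the values given here, no measured pair differs in one place, so the size of this step cannot be read from a neighbour. Given that the three varied amines of compound 1, compound 2 and compound 3 all landed close together, a modest weakening is expected from compound 3 to compound 4, a 2.1-fold higher number from compound 3 to compound 4 (0.31 log units; beyond the scatter), near the edge of the scatter. Compound 4 is therefore estimated at 80 nM in this assay, within 25 nM to 250 nM.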

Compound 4, half-maximal inhibitory concentration: 125 nM
Compound 4: the middle estimate sits 1.6-fold (0.19 log units) below what was measured, and the stated range covers the measured number.
By their numbers in this assay, from the lowest: compounds 1, 3 and 2 (each within the scatter of the next); then compound 4.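

The step of a 3.2-fold higher number from compound 3 to compound 4 (0.51 log units; beyond the scatter) in this assay shows that the amine on the carbonyl can matter, since compound 3 had stood within the scatter of both compound 1 and compound 2, whereas this change goes beyond it. The hydrogen-bond donor and acceptor counts are the same for the group that leaves and the group that enters, and neither carries a net charge, so the change lies elsewhere: a five-membered ring replaces a six-membered one, there are fewer heavy atoms, the hydroxyl sits on the ring rather than on a side chain, and a defined stereocentre appears. No measurement given here explains the loss, so its cause remains unassigned.

These changes arrive together, so the compounds shown leave open which of them carries the step. A 2-(2-hydroxyethyl)pyrrolidin-1-yl group or a 4-hydroxypiperidin-1-yl group on the same carbonyl carbon would help to separate ring size from hydroxyl placement, and the opposite enantiomer of the 3-hydroxypyrrolidin-1-yl group would address the stereocentre.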